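The source may hold more compounds than are shown below. What is called first, only, known or untested is meant among the compounds shown, and "the series" means these compounds.

Compound 1 `c1coc(-c2ccccc2OCC2=NCCN2)c1` has been tested in a functional assay for activation of Alpha-1D adrenergic receptor (Homo sapiens), read by calcium flux (a higher number here means that more compound is needed for the effect, a lower number that less compound is needed), and there compound 1 gives only < 100000 nM, which is a limit of the assay rather than a number. For the measured compounds named here, compound 2 `c1ccc(-c2ccsc2)c(OCC2=NCCN2)c1` is its one measured neighbour; in this assay compound 2 gives 12.6 nM. The step that the limit leaves unreadable from compound 1 to compound 2 cannot be read because the limit of < 100000 nM in this assay, at which 1 of the 2 values shown sits, fixes only one side of it. Compound 3 `Cc1cc(-c2ccccc2OCC2=NCCN2)sn1` has not yet been measured. It differs from compound 1 by 3-methyl-1,2-thiazol-5-yl in place of furan-2-yl on an aromatic carbon. Going by the values given here, only the step from compound 1 to compound 2 changes the same position, and since its size is not readable, no measured step sets the size or direction of the present change; the value of compound 2 shows merely that another five-membered aromatic ring in this place can give a low value. Compound 3 is therefore expected near 500 nM, within 20 nM to 20000 nM, an expected step that the limit leaves unreadable from compound 1 to compound 3 that the limit leaves wide open.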

Compound 3, half-maximal effective concentration: < 100000 nM
Compound 3: no number, only a limit; the forecaster's own chance of this, stated with the estimate: 20%; the middle value is on the limit's open side.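

No new step can be read for compound 3, against either compound 1 or compound 2, because its result in this assay is a limit and not a number: the limit of < 100000 nM in this assay, at which 2 of the 3 values shown sit.

The compounds shown leave open whether furan-2-yl and 3-methyl-1,2-thiazol-5-yl differ at all in this assay, and how far either compound 1 or compound 3 lies from compound 2.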